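The source may report more compounds than this note shows. Statements on the series, on what has been measured and on what is new or still open speak of the compounds shown alone.

Measured compounds and their numbers in a functional assay on SW-620 cells (Homo sapiens) for cytotoxicity, read by MTT assay, with a stated time of 72 h; on this read-out lower numbers stand for stronger inhibition and higher numbers for weaker inhibition:

Compound 1 `COc1cccc(/C=C2\CCC/C(=C\c3cccc(Cl)c3Cl)C2=O)c1OC` gives 16300 nM.
Compound 2 `COc1cccc(/C=C2\CCC/C(=C\c3ccc(Cl)c(Cl)c3)C2=O)c1OC` gives 10000 nM.
Compound 3 `COc1ccc(/C=C2\CCC/C(=C\c3ccc(Cl)cc3)C2=O)cc1OC` gives 5900 nM.

Compound 3 has the lowest number of the three. Its nearest neighbour is compound 2, whose number is higher by an amount within the scatter, so the two cannot be ranked against each other. Among the measured compounds shown here, compound 1 stands further away, beyond the scatter, and is the only compound that compound 3 clearly beats.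

Compound 4 `COc1ccc(/C=C2\CCC/C(=C\c3cccc(Cl)c3Cl)C2=O)cc1OC` has not been measured. It differs from compound 3 in one place: 2,3-dichlorophenyl in place of 4-chlorophenyl on a double-bonded chain carbon bound to a double-bonded ring carbon.

For the measured compounds named here, only one measured step exists, and it does not match this change. Going from compound 1 to compound 2, a 1.6-fold lower number from compound 1 to compound 2 (0.21 log units; within the scatter). That step compares two dichlorophenyl groups with each other, on a core that also differs from the core of compound 3, so it bears on the change from compound 3 to compound 4 only loosely. What the numbers do show is that compound 1, which carries the 2,3-dichlorophenyl entering here, has the highest number of the three, while compound 3 with 4-chlorophenyl has the lowest.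

The estimate therefore points to a somewhat higher number for compound 4, with wide uncertainty: compound 4 is expected at 10000 nM, between 4000 nM and 25000 nM, which would mean an expected step of a 1.7-fold higher number from compound 3 to compound 4 (0.23 log units; within the scatter).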

Compound 4, half-maximal inhibitory concentration: 10800 nM
Estimate against measurement, compound 4: 1.1-fold (0.03 log units) below, within the range that was stated.
By their numbers in this assay, from the lowest: compounds 3, 2, 4 and 1 (each within the scatter of the next, the first and the last beyond it).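

On a double-bonded chain carbon bound to a double-bonded ring carbon, the swap of 4-chlorophenyl for 2,3-dichlorophenyl now has a direct reading on a single core: in this assay it gives a 1.8-fold higher number from compound 3 to compound 4 (0.26 log units; within the scatter), so compound 3 and compound 4 cannot be ranked against each other. The earlier comparison, a 1.6-fold lower number from compound 1 to compound 2 (0.21 log units; within the scatter), set two dichlorophenyl groups against each other on a different core and could not speak to a 4-chlorophenyl group; at this place, both changes shown now stay within the scatter. No measurement is available that explains the values of compound 3 or compound 4.

The compounds shown carry only chlorinated phenyl groups at this place, so it remains open whether a group of another kind, such as a dimethylamino-substituted phenyl or a benzoic acid, would move the number in this assay beyond the scatter. It is also open whether the step seen here would be repeated on the core of compound 1, where 4-chlorophenyl does not appear among the compounds shown.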